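From cyclopropyl to (oxolan-2-yl)methyl on the amino nitrogen

The compounds below may be only part of what the source reports. "The series", "measured", "known", "first", "only" and "open" are said of these compounds alone.

In an ADME assay on MT4 cells (Homo sapiens) for cytotoxicity, read by MTT assay, with a stated time of 5 days (on this read-out lower numbers stand for higher toxicity in this test and higher numbers for lower toxicity in this test), compound 1 (`C=CCNc1cc(Oc2c(C)cc(/C=C/C#N)cc2C)nc(Nc2ccc(C#N)cc2)n1`) reads 3050 nM and compound 2 (`Cc1cc(/C=C/C#N)cc(C)c1Oc1cc(NC2CC2)nc(Nc2ccc(C#N)cc2)n1`) reads 3000 nM with no separation beyond the scatter. Compound 2 therefore stands with compound 1 at the low end of the three numbers, while compound 3 (`Cc1cc(/C=C/C#N)cc(C)c1Oc1cc(NCC2CCCO2)nc(Nc2ccc(C#N)cc2)c1`) reads 73600 nM well clear of both.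

The next step leads to compound 4 (`Cc1cc(/C=C/C#N)cc(C)c1Oc1cc(NCC2CCCO2)nc(Nc2ccc(C#N)cc2)n1`), where (oxolan-2-yl)methyl takes the place of cyclopropyl on a nitrogen on an aromatic ring. The change counts as (oxolan-2-yl)methyl in place of cyclopropyl on a nitrogen on an aromatic ring in full.

Among the compounds with values here, the one measured step at this nitrogen is a 1.0-fold lower number from compound 1 to compound 2 (0.01 log units; within the scatter) and it replaces allyl with cyclopropyl. That step stays within the scatter, but it does not involve the entering group. Compound 3 at 73600 nM does carry ((oxolan-2-yl)methyl)amino, on a core that differs from the core of compound 4, so it is only indirect support for a higher number. Within the data shown here, no measured pair isolates this group on the shared core.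

The expected move is a 4.0-fold higher number from compound 2 to compound 4 (0.60 log units; beyond the scatter) and it is estimated to fall short of the full gap seen at compound 3. For compound 4 the estimate is 12000 nM with 3000 nM to 60000 nM as the expected range.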

Compound 4, half-maximal cytotoxic concentration: > 268000 nM
Compound 4: a limit, no number; the forecaster's own chance of this, stated with the estimate: 15%; at least 22-fold (1.34 log units) between middle value and limit.
By their numbers in this assay, from the lowest: compounds 2 and 1 (each within the scatter of the next); then compound 3. At a limit, above all of these: compound 4.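

Compound 4 stands at a limit of the assay, not at a number: the limit of > 268000 nM in this assay, at which 1 of the 4 values shown sits. In this assay, the exchange on the amino nitrogen gives an at least 89-fold higher number from compound 2 to compound 4 (1.95 log units; beyond the scatter), and the comparison with the allyl compound gives an at least 87-fold higher number from compound 1 to compound 4 (1.94 log units; beyond the scatter). The earlier step at this nitrogen, a 1.0-fold lower number from compound 1 to compound 2 (0.01 log units; within the scatter), showed no separation, so only now is a substituent at this position seen to shift the read-out on the shared core, with (oxolan-2-yl)methyl setting compound 4 apart from both cyclopropyl and allyl.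

As far as these compounds go, with a limit at one end, the true size of both new steps stays open, as does whether the ring oxygen of (oxolan-2-yl)methyl is needed for the shift, which a cyclopentylmethyl group or a longer chain ending in an amine on the shared core would help to separate. From the compounds shown here alone, compound 3 gives 73600 nM with the same group on a different core, and how far that core difference alone moves the read-out also remains open.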